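The source may hold more compounds than are shown below. What is called first, only, known or untested is meant among the compounds shown, and "the series" means these compounds.

Three compounds share one core and have so far been examined in a physicochemical assay for acid dissociation. Compound 1 `COc1ccc(Oc2ccc3c(NCCCNCc4cc(F)ccc4OC)ccnc3c2)cc1` gives 9.28. Compound 2 `COc1ccc(F)cc1CNCCCNc1ccnc2cc(-c3ccc(F)cc3)ccc12` gives 9.47. Compound 3 `COc1ccc(F)cc1CNCCCNc1ccnc2cc(CC(C)C)ccc12` gives 9.47, which puts compound 3 level with compound 2 at the digits shown, and the pair together at the high end of the three numbers, with compound 1 the furthest away. Every step among these three sits inside the usual scatter: a number 0.19 log units higher from compound 1 to compound 2 (within the scatter), a number 0.19 log units higher from compound 1 to compound 3 (within the scatter) and no change at the digits printed from compound 2 to compound 3 (within the scatter).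

The next compound, compound 4 `COc1ccc(F)cc1CNCCCNc1ccnc2cc(Oc3ccccc3OC)ccc12`, differs from compound 3 at one place: 2-methoxyphenoxy in place of isobutyl on an aromatic carbon. Among the compounds with values here, the step that bears most directly on this change is the one between compound 1 and compound 3, because a number 0.19 log units higher from compound 1 to compound 3 (within the scatter) already compares a methoxy-bearing phenoxy group against isobutyl at the same ring carbon and shows only a shift inside the scatter. The move back to a phenoxy group, now carrying its methoxy as 2-methoxyphenoxy, is therefore expected to give at most a small shift in this assay, if any, and if anything a slightly lower number. Compound 4 is estimated at 9.33, within a range from 9.05 to 9.6, which as a step from compound 3 means a number 0.14 log units lower from compound 3 to compound 4 (within the scatter).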

Compound 4, acid dissociation constant: 9.28
The estimate for compound 4 lay 0.05 log units above the measured number; the measured number falls inside the stated range.
By their numbers in this assay, from the lowest: compounds 1, 4, 2 and 3 (each within the scatter of the next).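

In this assay the 2-methoxyphenoxy group, with its six-membered aromatic ring and 2 hydrogen-bond acceptors, can take the place of isobutyl, which has no ring, and the result is a small step (a number 0.19 log units lower from compound 3 to compound 4 (within the scatter)). Putting the same group in place of 4-fluorophenyl on this aromatic carbon gives a matching step (a number 0.19 log units lower from compound 2 to compound 4 (within the scatter)), so the readings for groups joined through oxygen and for those joined directly stay within the scatter across these compounds. The new comparison is within the phenoxy group itself: 2-methoxyphenyl in place of 4-methoxyphenyl on the oxygen gives (no change at the digits printed from compound 1 to compound 4 (within the scatter)), so moving the methoxy group around that outer ring leaves the number where it was. No supporting measurement is available to explain these readings.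

All the groups shown here at this aromatic carbon are uncharged and have no hydrogen-bond donors, so it remains open whether an amine or a carboxylic acid there would also stay within the scatter. On these data alone, it is equally open whether a much smaller substituent, such as a single fluorine atom or a nitrile, would give a number outside the narrow band seen so far.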